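The source may hold more compounds than are shown below. What is called first, only, known or untested is meant among the compounds shown, and "the series" means these compounds.

Working notes on the series. Within the data shown here, in a functional assay on A549 cells (Homo sapiens) for inhibition, read by MTT assay, with a stated time of 48 h (a higher number here means a weaker inhibitor, a lower number a stronger inhibitor), compound 1 `CS(=O)(=O)Nc1ccc(-n2cc(COc3ccccc3Cl)nn2)cc1Oc1ccccc1` gives 53800 nM, which is the only number available so far. Compound 2 `Cc1ccc(-c2cn(-c3ccc(NS(C)(=O)=O)c(Oc4ccccc4)c3)nn2)cc1` offers no anchor: in this assay compound 2 stands as "not determined" (no result reported), so it has no place on the scale and no step can be read from it. Compound 3 `CS(=O)(=O)Nc1ccc(-n2cc(COc3ccc(Cl)cc3)nn2)cc1Oc1ccccc1` is still unmeasured. The structural change is (4-chlorophenoxy)methyl in place of 4-methylphenyl on an aromatic carbon. It puts (4-chlorophenoxy)methyl in place of 4-methylphenyl on an aromatic carbon of the five-membered aromatic ring with 3 nitrogen.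

Among the measured compounds shown here, the series holds no measured step, so the effect of this change in this assay cannot be taken from data. For the measured compounds named here, the expectation rests instead on compound 1 at 53800 nM, the single measured value. Compound 3 is expected to fall close to that value, with no step beyond the usual scatter in either direction, and so to remain a weak inhibitor. The estimated value for compound 3 is 40000 nM, with an expected range of 15000 nM to 100000 nM.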

Compound 3, half-maximal inhibitory concentration: 7100 nM
Beside the measured number, compound 3's estimate is 5.6-fold (0.75 log units) above it; measured number outside the range, below it.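

Among these compounds, the only readable step in this assay replaces 2-chlorophenyl with 4-chlorophenyl on the oxygen on a saturated carbon and gives a 7.6-fold lower number from compound 1 to compound 3 (0.88 log units; beyond the scatter), a modest step beyond the scatter. This shows that the (chlorophenoxy)methyl group on the aromatic carbon of the five-membered aromatic ring with 3 nitrogen is sensitive to where the chlorine stands on its phenyl ring, even with the atom count unchanged and the rest of the core of compound 1 held constant. The exchange of 4-methylphenyl for (4-chlorophenoxy)methyl cannot be read, as compound 2 has no number on the scale, and no evidence on hand bears on the cause of the step from 2-chlorophenyl to 4-chlorophenyl.

The compounds shown leave open whether the 4-chlorophenyl result is specific to chlorine, since they include no 4-fluorophenyl, 4-methoxyphenyl or unsubstituted phenyl on the same oxygen. Also open, on these data alone, is how the position responds to a 3-chlorophenyl group, to a longer chain between the ring and the oxygen, or to an amine or a carboxylic acid on the phenyl ring.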